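Cyano for diethylcarbamoyl: notes on the next step

The compounds below may be only part of what the source reports. "The series", "measured", "known", "first", "only" and "open" are said of these compounds alone.

In a functional assay on T47D cells (Homo sapiens) for cytotoxicity, read by colorimetric assay and MTT assay (a higher number here means a weaker inhibitor, a lower number a stronger inhibitor), compound 1 (`CCOC(=O)Cn1c(=O)c(-c2ccc(OC)cc2)cc2c(OC)cc(OC)cc21`) gives 10000 nM as its value. Compound 2 (`CCN(CC)C(=O)Cn1c(=O)c(-c2ccc(OC)cc2)cc2c(OC)cc(OC)cc21`) reads 10000 nM and so stands level with compound 1, its nearest neighbour. The change to compound 3 (`COc1ccc(-c2cc3c(OC)cc(OC)cc3n(CC#N)c2=O)cc1`) is cyano in place of diethylcarbamoyl on a saturated chain carbon bound to an aromatic nitrogen and amounts to cyano in place of diethylcarbamoyl on a saturated chain carbon bound to an aromatic nitrogen. Among the compounds with values here, one measured step bears on it: no change at the digits printed from compound 1 to compound 2 (within the scatter) for diethylamino in place of ethoxy on a carbonyl carbon, which lies within the scatter. That step keeps the carbonyl carbon, whereas here the carbonyl leaves with the diethylcarbamoyl, so the guide is thin. The expected step is no change at the digits printed from compound 2 to compound 3 (within the scatter) and no shift beyond the scatter is expected in this assay for this change. For compound 3 the estimated value is 10000 nM with an expected range from 4000 nM to 25000 nM in these notes.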

Compound 3, half-maximal inhibitory concentration: 10000 nM
Compound 3: the middle estimate sits on the measured number at the digits printed; the measured number falls inside the stated range.
By their numbers in this assay, from the lowest: compounds 1, 2 and 3 (each within the scatter of the next).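

In this assay the group on a saturated chain carbon bound to an aromatic nitrogen now loses its carbonyl, and cyano in place of diethylcarbamoyl gives no change at the digits printed from compound 2 to compound 3 (within the scatter) on the shared core. Cyano in place of ethoxycarbonyl gives the same picture, with no change at the digits printed from compound 1 to compound 3 (within the scatter) at this position, so the read stays level whether or not the carbonyl is kept. Nothing measured here speaks to why the read stays level.

Going by these compounds, whether a carboxylic acid, an amine or a longer alkyl chain at this place would move the value of compound 3 away from 10000 nM stays open. Also open, on these data alone, is whether any change elsewhere on the shared core would shift this assay beyond the scatter.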